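Moving bromine on the sulfur-bound phenyl ring

The source may report more compounds than this note shows. Statements on the series, on what has been measured and on what is new or still open speak of the compounds shown alone.

Of the compounds shown here, three sharing one core have been tested in a functional assay on the whole organism for inhibition, with Mus musculus as the target, at a dose of 3 mg/kg; on this read-out higher numbers stand for more inhibition at the one dose given (going by the name of the read-out) and lower numbers for less inhibition. Compound 2 `CCCCN(O)C(=O)Nc1cc([C@@H]2CC[C@@H](c3cc(OC)c(OC)c(OC)c3)O2)cc(OC)c1OCCSc1ccc(Cl)cc1` gives 39%, the highest of the three numbers. Compound 1 `CCCCN(O)C(=O)Nc1cc([C@@H]2CC[C@@H](c3cc(OC)c(OC)c(OC)c3)O2)cc(OC)c1OCCSc1ccc(Br)cc1` gives 3%, and compound 3 `CCCCN(O)C(=O)Nc1cc([C@@H]2CC[C@@H](c3cc(OC)c(OC)c(OC)c3)O2)cc(OC)c1OCCS(=O)(=O)c1c(F)c(F)cc(F)c1F` gives 12%; both lie beyond the scatter below compound 2. For the measured compounds named here, the one single-point step among them, a number 36 percentage points higher from compound 1 to compound 2 (beyond the scatter), shows that swapping the halogen on that ring can move this read-out a long way.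

Compound 4 `CCCCN(O)C(=O)Nc1cc([C@@H]2CC[C@@H](c3cc(OC)c(OC)c(OC)c3)O2)cc(OC)c1OCCSc1cccc(Br)c1` differs from compound 2 in one place: 3-bromophenyl in place of 4-chlorophenyl on a sulfur. Going by the values given here, this change brings bromine back onto the ring, but at a different position, and no measured pair shows what moving a halogen around the ring does. Because compound 1 with bromine gives 3% while compound 2 with chlorine gives 39%, a drop is expected, though its size is uncertain. For compound 4 the expected step is a number 24 percentage points lower from compound 2 to compound 4 (beyond the scatter). Compound 4 is therefore estimated at 15%, within a range from 0% to 40%.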

Compound 4, a percentage reported as inhibition, in the whole organism at one dose (the size of the read-out at that dose, not a potency): 40%
Compound 4: the middle estimate sits 25 percentage points below what was measured, and the stated range covers the measured number.
By their numbers in this assay, from the lowest: compounds 1 and 3 (each within the scatter of the next); then compounds 2 and 4 (each within the scatter of the next).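

In this assay, moving bromine from 4-bromophenyl to 3-bromophenyl on the sulfur gives a number 37 percentage points higher from compound 1 to compound 4 (beyond the scatter) and so shows that the read-out depends on where the bromine sits, not only on whether this halogen is present. Bromine therefore need not bring a low number at this position: 3-bromophenyl in place of 4-chlorophenyl gives a number 1 percentage points higher from compound 2 to compound 4 (within the scatter) and leaves these two groups indistinguishable here. No measurement at hand explains why the place of the bromine matters so much.

Still open, on these data alone, is what 3-chlorophenyl would give on the same sulfur, and so whether the position of chlorine matters as that of bromine does. Also open, as far as these compounds go, is how an amine or a carboxylic acid on this ring, or a longer chain carrying the sulfur, would read in this assay.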